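The source may hold more compounds than are shown below. What is called first, only, known or untested is meant among the compounds shown, and "the series" means these compounds.

Compounds measured in a functional assay on CCRF-CEM cells (Homo sapiens) for inhibition, read by cell counting, with a stated time of 3 days; on this read-out higher numbers stand for weaker inhibition and lower numbers for stronger inhibition:
compound 1 `CCc1ccc(-c2nn3cc(-c4cccc(N)c4)nc3s2)cc1` gives 22000 nM;
compound 2 `C=C(Br)C(=O)Nc1cccc(-c2cn3nc(-c4cccs4)sc3n2)c1` gives 410 nM;
compound 3 `C=C(Br)C(=O)Nc1cccc(-c2cn3nc(-c4ccc(OC)cc4)sc3n2)c1` gives 1200 nM.

Compound 3 stands second highest of the three, with compound 2 its nearest neighbour and compound 1 far above it. Compound 4 `C=C(Br)C(=O)Nc1cccc(-c2cn3nc(-c4ccc(CC)cc4)sc3n2)c1` is to be measured. Relative to compound 3 the change is ethyl in place of methoxy on an aromatic carbon. Among the measured compounds shown here, the only step bearing on this position is a 2.9-fold higher number from compound 2 to compound 3 (0.47 log units; beyond the scatter), a modest shift for a change of the whole aryl group; compound 1 also carries 4-ethylphenyl, but its core and its other substituent differ, so its value is not a direct guide. For a small swap of one two-atom group for another, a step within or only slightly beyond the scatter is expected, in the lower direction if any: a 1.2-fold lower number from compound 3 to compound 4 (0.08 log units; within the scatter). Compound 4 is estimated at 1000 nM, range 400 nM to 3000 nM.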

Compound 4, half-maximal inhibitory concentration: 3400 nM
Estimate against measurement, compound 4: 3.4-fold (0.53 log units) below; measured number above the stated range.
By their numbers in this assay, from the lowest: compound 2; then compound 3; then compound 4; then compound 1.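

In this assay this position responds even to a swap of methoxy for ethyl: a 2.8-fold higher number from compound 3 to compound 4 (0.45 log units; beyond the scatter) is about as large as the change of the whole aryl group, a 2.9-fold higher number from compound 2 to compound 3 (0.47 log units; beyond the scatter). The 4-ethylphenyl group lies further from thiophen-2-yl, with an 8.3-fold higher number from compound 2 to compound 4 (0.92 log units; beyond the scatter), so these three compounds rank thiophen-2-yl, 4-methoxyphenyl, 4-ethylphenyl. With 4-ethylphenyl present, (1-bromoethenyl)carbonyl in place of hydrogen on the nitrogen goes with a 6.5-fold lower number from compound 1 to compound 4 (0.81 log units; beyond the scatter), although the core of compound 1 differs.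

Nothing at hand explains these steps. As far as these compounds go, whether an amine, a hydroxyl or a longer chain such as propyl at this position would follow the same ranking stays open.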